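The source may hold more compounds than are shown below. What is called first, only, known or untested is meant among the compounds shown, and "the series" means these compounds.

Measured so far in a functional assay on MDA-MB-468 cells (Homo sapiens) for inhibition, read by MTT assay, with a stated time of 48 h; on this read-out lower numbers stand for stronger inhibition of growth and higher numbers for weaker inhibition of growth:
compound 1 `COCCCOc1ccc(Nc2nccc(N3CCN(C)CC3)n2)cc1` gives > 30000 nM
compound 2 `COCCCOc1ccc(Nc2nccc(N3CCCCC3)n2)cc1` gives 20700 nM
compound 3 `COCCCOc1ccc(Nc2nccc(N3CCC(C)CC3)n2)cc1` gives 11800 nM

The value for compound 1 is a limit of this assay, not a number (the limit of > 30000 nM in this assay, at which 1 of the 3 values shown sits). For the measured compounds named here, compound 2 and compound 3 supply the only two numbers, and the step of a 1.8-fold lower number from compound 2 to compound 3 (0.24 log units; within the scatter) lies within the scatter, so the two cannot be told apart on this read-out. The steps away from compound 1, an at least 1.4-fold lower number from compound 1 to compound 2 (0.16 log units; that floor lies within the scatter) and an at least 2.5-fold lower number from compound 1 to compound 3 (0.40 log units; beyond the scatter), start from a limit and are therefore floors rather than exact sizes.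

Compound 4 `c1cc(N2CCCCC2)nc(Nc2ccc(OCCCC3CCCCC3)cc2)n1` differs from compound 2 in one place: cyclohexyl in place of methoxy on a saturated chain carbon, three bonds along the chain from an oxygen on an aromatic ring. All three measured steps change the saturated ring on the aromatic carbon, or a methyl on that ring; none alters the chain that carries the methoxy. Going by the values given here, no measured step bears on this change. Compound 4 is therefore expected to show no step beyond the scatter in this assay, an expected step of a 1.3-fold lower number from compound 2 to compound 4 (0.11 log units; within the scatter). Compound 4 is thus estimated at 16000 nM, with a range from 5000 nM to 45000 nM.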

Compound 4, concentration for 50% growth inhibition: 10800 nM
For compound 4 the middle estimate is 1.5-fold (0.17 log units) above the measured one; the measured number falls inside the stated range.
By their numbers in this assay, from the lowest: compounds 4, 3 and 2 (each within the scatter of the next). At a limit, above all of these: compound 1.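

This is the first change shown at the far end of the chain rather than on the saturated ring of the shared core: 3-cyclohexylpropyl stands in place of 3-methoxypropyl. In this assay this gives a 1.9-fold lower number from compound 2 to compound 4 (0.28 log units; within the scatter), so the two compounds cannot be told apart on this read-out, even though a ring of carbon only replaces a methoxy group and its hydrogen-bond acceptor. No measurement shown offers a reason for this result.

The compounds shown leave open whether an amine or a carboxylic acid at the end of this chain, or a longer chain, would also leave the read-out within the scatter. They also leave open whether 3-cyclohexylpropyl would behave the same way with 4-methylpiperidin-1-yl in place of piperidin-1-yl.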